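Swapping the ring amine on a dithiocarbamate antiproliferative

A few compounds are considered here, and "the series" means these few. Any claim that something is new, unique, unknown or untested is made for them only; others in the source may bear on it.

Measured so far:
Compound 1 `Nc1ccccc1NC(=O)c1ccc(CSC(=S)N2CCCc3ccccc32)cc1` gives 81.5%
Compound 2 `Nc1ccccc1NC(=O)c1ccc(CSC(=S)N2CCN(c3ccc(F)cc3)CC2)cc1` gives 76.3%
Compound 3 `CC1CCN(C(=S)SCc2ccc(C(=O)Nc3ccccc3N)cc2)CC1` gives 87.4%

All three were read in a functional assay on A-375 cells (Homo sapiens) for antiproliferative activity, read by CCK-8 assay, with a stated time of 72 h, tested at 8 uM; on this read-out higher numbers stand for a stronger effect at the one concentration tested and lower numbers for a weaker effect. Compound 1 stands second highest of the three numbers; compound 2 lies a little lower and compound 3 a little higher, and both gaps fall within the usual scatter, so no order can be claimed among them. Compound 4 `CN1CCN(C(=S)SCc2ccc(C(=O)Nc3ccccc3N)cc2)CC1` has not been measured yet. It differs from compound 1 by 4-methylpiperazin-1-yl in place of 1,2,3,4-tetrahydroquinolin-1-yl on a thiocarbonyl carbon. Going by the values given here, the only step of the same kind already seen, a number 5.9 percentage points higher from compound 1 to compound 3 (within the scatter), exchanged the same group for another ring and stayed within the scatter. A step of about that size, or none beyond the scatter, is therefore expected, a number 1.5 percentage points lower from compound 1 to compound 4 (within the scatter). Compound 4 is estimated at 80%, between 68% and 90%.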

Compound 4, a percentage reported as inhibition, at one concentration (the size of the read-out at that concentration, not a potency): 91.6%
Beside the measured number, compound 4's estimate is 11.6 percentage points below it; measured number above the stated range.
By their numbers in this assay, from the lowest: compounds 2, 1, 3 and 4 (each within the scatter of the next, the first and the last beyond it).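

Going by these compounds alone, this position does respond to the ring amine: 4-methylpiperazin-1-yl in place of 1,2,3,4-tetrahydroquinolin-1-yl on the thiocarbonyl carbon gives the first such step beyond the scatter (a number 10.1 percentage points higher from compound 1 to compound 4 (beyond the scatter)). Methyl in place of 4-fluorophenyl on the ring amine nitrogen also gives a step beyond the scatter (a number 15.3 percentage points higher from compound 2 to compound 4 (beyond the scatter)). The change from 4-methylpiperidin-1-yl to 4-methylpiperazin-1-yl stays within the scatter (a number 4.2 percentage points higher from compound 3 to compound 4 (within the scatter)), so these two rings cannot be ranked.

No measurement here explains these steps. Going by these compounds, how a morpholine ring or an open-chain diethylamine would fare at this position remains open.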